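Notes on the aryl substituent step to compound 4

The source may report more compounds than this note shows. Statements on the series, on what has been measured and on what is new or still open speak of the compounds shown alone.

Measured in a functional assay on SMMC-7721 cells (Homo sapiens) for inhibition, read by CCK-8 assay; a higher number here means a weaker inhibitor, a lower number a stronger inhibitor:
compound 1 `Oc1ccccc1/C=N/c1nnc(SCc2nnc(-c3ccc(F)cc3)o2)s1` — 13100 nM
compound 2 `Oc1ccccc1/C=N/c1nnc(SCc2nnc(-c3ccc(Cl)cc3)o2)s1` — 2840 nM
compound 3 `Cc1cccc(-c2nnc(CSc3nnc(/N=C/c4ccccc4O)s3)o2)c1` — 4550 nM

Among the measured compounds shown here, compound 2 gives the lowest of the three numbers; compound 3 lies within the scatter of it, and only the step of a 4.6-fold lower number from compound 1 to compound 2 (0.66 log units; beyond the scatter) is beyond the scatter.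

Compound 4 `Cc1ccc(-c2nnc(CSc3nnc(/N=C/c4ccccc4O)s3)o2)cc1` differs from compound 2 by methyl in place of chloro on an aromatic carbon. Bearing on this, a 4.6-fold lower number from compound 1 to compound 2 (0.66 log units; beyond the scatter) and a 2.9-fold lower number from compound 1 to compound 3 (0.46 log units; beyond the scatter) both lowered the number when the fluoro was replaced, while a 1.6-fold higher number from compound 2 to compound 3 (0.20 log units; within the scatter) shows that a chloro and a methyl on the same ring give numbers within the scatter. A step within the scatter, if anything slightly upward, is therefore expected for a 1.2-fold higher number from compound 2 to compound 4 (0.09 log units; within the scatter).

Compound 4 is estimated at 3500 nM, with a range of 1500 nM to 8500 nM in this assay.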

Compound 4, half-maximal inhibitory concentration: 37100 nM
Beside the measured number, compound 4's estimate is 11-fold (1.03 log units) below it; the whole stated range lies below it.
By their numbers in this assay, from the lowest: compounds 2 and 3 (each within the scatter of the next); then compound 1; then compound 4.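

Methyl in place of chloro, para to a large group, is no neutral exchange: this assay shows a 13-fold higher number from compound 2 to compound 4 (1.12 log units; beyond the scatter) for it. The place of the methyl counts too, with an 8.2-fold higher number from compound 3 to compound 4 (0.91 log units; beyond the scatter) for 4-methylphenyl in place of 3-methylphenyl, and fluoro no longer gives the highest number, with a 2.8-fold higher number from compound 1 to compound 4 (0.45 log units; beyond the scatter) for methyl in place of fluoro. Nothing at hand accounts for these steps.

Open, as far as these compounds go, is whether the high number is particular to 4-methylphenyl or extends to other groups at this place. A methoxy, an amine or a carboxylic acid on the same ring would test this.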